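A few compounds are considered here, and "the series" means these few. Any claim that something is new, unique, unknown or untested is made for them only; others in the source may bear on it.

For the measured compounds named here, in an ADME assay on microsomes from liver (Homo sapiens) for pharmacokinetics, using NADPH, with a stated time of 30 min, tested at 1 uM (on this read-out higher numbers stand for fast clearance and lower numbers for slow clearance), compound 1 (`C[C@H](Nc1ncnc(N)c1C#N)c1nc2ccc(F)cc2c(-c2ccccn2)c1-c1ccccn1`) gives 47 mL.min-1.g-1, the only plain number measured so far. Compound 2 (`C[C@H](Nc1ncnc(N)c1C#N)c1nc2ccc(F)cc2c(C(N)=O)c1-c1ccccc1`) gives < 14 mL.min-1.g-1, which is a limit of the assay and not a number. Compound 3 (`CNC(=O)c1c(-c2ccccc2)c([C@H](C)Nc2ncnc(N)c2C#N)nc2ccc(F)cc12`) gives < 14 mL.min-1.g-1, which is also a limit. Compound 3 therefore stands at the limit of < 14 mL.min-1.g-1 in this assay, at which 2 of the 3 values shown sit, with no exact value to start from.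

Compound 4 (`C[C@H](Nc1ncnc(N)c1C#N)c1nc2ccc(F)cc2c(C(=O)N(C)C)c1-c1ccccc1`) differs from compound 3 by a single change: methyl in place of hydrogen on an amide-type nitrogen. This is methyl in place of hydrogen on an amide-type nitrogen, turning methylcarbamoyl into dimethylcarbamoyl. Going by the values given here, the one measured step of the same kind is a step that the two limits leave unreadable from compound 2 to compound 3, so it offers no size to carry over. With no measured size to go on, no shift beyond the scatter is expected in this assay, in either direction. The expected change is a number no lower from compound 3 to compound 4 (the limit leaves the size open). Compound 4 may well be reported only as a limit too. Compound 4 is estimated at 14 mL.min-1.g-1, with an expected range of 7 mL.min-1.g-1 to 30 mL.min-1.g-1.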

Compound 4, intrinsic clearance in microsomes: 198 mL.min-1.g-1
Estimate against measurement, compound 4: 14-fold (1.15 log units) below; measured number outside the range, above it.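

In this assay, the amide-type nitrogen proves to be a sensitive place, since methyl in place of hydrogen there gives an at least 14-fold higher number from compound 3 to compound 4 (1.15 log units; beyond the scatter). Replacing the amino group on the carbonyl carbon with dimethylamino gives an at least 14-fold higher number from compound 2 to compound 4 (1.15 log units; beyond the scatter), so a fully substituted amide nitrogen can move this read-out well away from the limit of the assay, whereas the step between the two limits cannot be read. Nothing measured here accounts for the size of this jump.

As far as these compounds go, it remains open whether the high clearance of compound 4 is specific to dimethylcarbamoyl or would also appear with a longer chain, such as ethyl, on the amide nitrogen. From the compounds shown here alone, how a carboxylic acid would behave in place of the amide also remains open.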